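The source may report more compounds than this note shows. Statements on the series, on what has been measured and on what is new or still open speak of the compounds shown alone.

In a functional assay on MDA-MB-231 cells (Homo sapiens) for antiproliferative activity, read by MTT assay, with a stated time of 48 h (a lower number here means a stronger inhibitor, a higher number a weaker inhibitor), compound 1 `COC(=O)/C(=C/c1ccccc1)CN1C(=O)[C@@H](OC)[C@H]1c1ccc(Cl)cc1Cl` gives 19000 nM and compound 2 `COC(=O)/C(=C/c1ccccc1)CN1C(=O)[C@@H](OC)[C@H]1c1ccc(OC)cc1` gives 14000 nM on the same shared core. These two numbers lie within the scatter of each other, so compound 2 cannot be ranked against compound 1 and holds no clear place of its own. Compound 3 `COC(=O)/C(=C/c1ccccc1)CN1C(=O)[C@@H](OC)[C@H]1c1cccc([N+](=O)[O-])c1` keeps that core and alters one group on a saturated ring carbon: 3-nitrophenyl in place of 4-methoxyphenyl on a saturated ring carbon is the difference from compound 2, with 3-nitrophenyl in place of 4-methoxyphenyl. For the measured compounds named here, only one measured step bears on this place, a 1.4-fold lower number from compound 1 to compound 2 (0.13 log units; within the scatter) and it involved another pair of groups. That step gives no sign that a swap here moves the number much, so no step beyond the scatter is expected in this assay in either direction. Going by the values given here, no tested compound carries a 3-nitrophenyl group, so this expectation rests on little and the range is kept wide. The expected change is a 1.1-fold higher number from compound 2 to compound 3 (0.03 log units; within the scatter) in this estimate. Compound 3 is estimated at 15000 nM with an expected range of 6000 nM to 35000 nM.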

Compound 3, half-maximal inhibitory concentration: 14400 nM
For compound 3 the middle estimate is 1.0-fold (0.02 log units) above the measured one, and the stated range covers the measured number.
By their numbers in this assay, from the lowest: compounds 2, 3 and 1 (each within the scatter of the next).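

In this assay, the change to the 3-nitrophenyl group gives a 1.0-fold higher number from compound 2 to compound 3 (0.01 log units; within the scatter), and the change from the 2,4-dichlorophenyl group gives a 1.3-fold lower number from compound 1 to compound 3 (0.12 log units; within the scatter). With this third group in place, all three substituted phenyl groups tested on this saturated ring carbon of the four-membered ring give numbers within the scatter of one another, so this assay does not separate them, even though the groups on the phenyl ring are chlorine, methoxy and nitro. Nothing at hand explains why these three groups read alike.

From the compounds shown here alone, all three groups are still phenyl rings, so it remains open whether an aminophenyl or carboxyphenyl group, a cyclohexyl ring or a longer alkyl chain at this carbon would shift the number beyond the scatter. Going by these compounds, the methoxy group on the neighbouring ring atom and the rest of the shared core also stay the same throughout, so it is equally open whether these groups would still read alike with an ethoxy group or an amine there instead.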